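Carboxy in Place of Trifluoromethyl on a Shared Core

This account rests on a few compounds, and the source may have more. Where it says the series, first, only, none or still open, it means among the compounds named here.

Compound 1 `Cc1n[nH]c(C(=O)O)c1Cc1cccc(-c2ccc(OC(F)(F)F)cc2)c1`: 300 nM
Compound 2 `Cc1n[nH]c(C(=O)O)c1Cc1cccc(-c2ccc(C(N)=O)cc2)c1`: 200 nM
Compound 3 `Cc1n[nH]c(C(=O)O)c1Cc1cccc(-c2ccc(C(F)(F)F)cc2)c1`: 400 nM

Of the compounds shown here, three of one shared core have been measured in an assay on isolated protein for inhibition of 2-Hydroxyacid oxidase 2 (Rattus norvegicus); a lower number here means a stronger inhibitor, a higher number a weaker inhibitor. Compound 3 gives the highest of the three numbers, yet its nearest neighbour is compound 1, with a 1.3-fold higher number from compound 1 to compound 3 (0.12 log units; within the scatter), and its furthest is compound 2, with a 2.0-fold higher number from compound 2 to compound 3 (0.30 log units; within the scatter). Both gaps lie within the scatter, so the three measured compounds cannot be ordered on these numbers.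

Compound 4 `Cc1n[nH]c(C(=O)O)c1Cc1cccc(-c2ccc(C(=O)O)cc2)c1` is not yet measured. It differs from compound 3 in one place: carboxy in place of trifluoromethyl on an aromatic carbon

For the measured compounds named here, two measured steps bear on this change. The step from trifluoromethoxy to carbamoyl, a 1.5-fold lower number from compound 1 to compound 2 (0.18 log units; within the scatter), and the step from carbamoyl to trifluoromethyl, a 2.0-fold higher number from compound 2 to compound 3 (0.30 log units; within the scatter), both stayed within the scatter, so swapping a fluorinated group for a group carrying a hydrogen-bond donor and acceptor at this position has so far moved nothing beyond the noise. Going by the values given here, the carboxy group, like carbamoyl, brings one donor and one acceptor, but no compound with carboxy at this position has been measured, so its own effect is unknown.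

On that basis compound 4 is expected to sit close to compound 3, with a step of a 1.6-fold lower number from compound 3 to compound 4 (0.20 log units; within the scatter) that stays within the scatter. The estimate for compound 4 in this assay is 250 nM, with a range from 100 nM to 700 nM.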

Compound 4, half-maximal inhibitory concentration: 1100 nM
Beside the measured number, compound 4's estimate is 4.4-fold (0.64 log units) below it; the whole stated range lies below it.
By their numbers in this assay, from the lowest: compounds 2, 1 and 3 (each within the scatter of the next); then compound 4.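

For the compounds shown here, at this position, on an aromatic carbon para to a large group, the exchanges among trifluoromethoxy, carbamoyl and trifluoromethyl had all stayed within the scatter in this assay, but carboxy is the first group to move the number beyond it, both against trifluoromethyl (a 2.8-fold higher number from compound 3 to compound 4 (0.44 log units; beyond the scatter)) and against trifluoromethoxy (a 3.7-fold higher number from compound 1 to compound 4 (0.56 log units; beyond the scatter)). The largest of these steps is the smallest change in structure, hydroxy in place of amino on a carbonyl carbon (a 5.5-fold higher number from compound 2 to compound 4 (0.74 log units; beyond the scatter)), so carbamoyl gives no guide to carboxy here, and compound 4 is the weakest of the four inhibitors. The position is therefore not indifferent to what it carries, though nothing available here accounts for the loss.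

The compounds shown leave open whether a methyl ester or a hydroxymethyl group at this position would stay with carbamoyl or fall with carboxy. They also leave open whether an amine there would give a similar step, which would show whether the loss is particular to the carboxylic acid.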